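Working notes on the step from compound 3 to compound 4

The source may report more compounds than this note shows. Statements on the series, on what has been measured and on what is new or still open speak of the compounds shown alone.

Measured so far in a functional assay on A549 cells (Homo sapiens) for antiproliferative activity, read by MTT assay, with a stated time of 48 h; a lower number here means a stronger inhibitor, a higher number a weaker inhibitor:
- Compound 1, `N#CC1=C(N)Oc2c(c3nc4ccccc4nc3c3ccccc23)C12C(=O)N(Cc1cnnn1-c1ccc([N+](=O)[O-])cc1)c1ccccc12`, gives the assay limit > 50000 nM.
- Compound 2, `N#CC1=C(N)Oc2c(c3nc4ccccc4nc3c3ccccc23)C12C(=O)N(Cc1cnnn1-c1ccc(N)cc1)c1ccccc12`, gives the assay limit > 50000 nM.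
- Compound 3, `CCOc1ccccc1-n1nncc1CN1C(=O)C2(C(C#N)=C(N)Oc3c(N)cc4nc5ccccc5nc4c32)c2ccccc21`, gives the assay limit > 50000 nM.

Compound 3 stands at the limit of this assay, as do the other two values, because of the limit of > 50000 nM in this assay, at which 3 of the 3 values shown sit. Within the data shown here, the one single-point step, a step that the two limits leave unreadable from compound 1 to compound 2, is unreadable between two limits and gives no size. Compound 4, `Cc1ccc(-n2nncc2CN2C(=O)C3(C(C#N)=C(N)Oc4c(N)cc5nc6ccccc6nc5c43)c3ccccc32)cc1Cl`, differs from compound 3 by 3-chloro-4-methylphenyl in place of 2-ethoxyphenyl on an aromatic nitrogen. Among the measured compounds shown here, no measured step bears on this change; nothing in the numbers points to a readable shift. Compound 4 is therefore expected to sit at the limit again, estimated at 60000 nM, range 15000 nM to 300000 nM, a step that the limit leaves unreadable from compound 3 to compound 4.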

Compound 4, half-maximal inhibitory concentration: 11800 nM
Compound 4: middle estimate off by 5.1-fold (0.71 log units), on the high side, and the stated range ends above it.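

Among these compounds, replacing 2-ethoxyphenyl with 3-chloro-4-methylphenyl on the aromatic nitrogen gives an at least 4.2-fold lower number from compound 3 to compound 4 (0.62 log units; beyond the scatter) in this assay, the first readable step. Compound 4 therefore shows that this position can move the read-out on the shared core. The size remains only a bound, because compound 3 sits at an assay limit: the limit of > 50000 nM in this assay, at which 3 of the 4 values shown sit.

Going by these compounds, whether the chlorine, the methyl or the loss of the ethoxy carries the step stays open. Also open, on these data alone, is what a carboxylic acid or a longer chain would give in place of the methyl.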